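Varying the chain on a shared core

This account rests on a few compounds, and the source may have more. Where it says the series, first, only, none or still open, it means among the compounds named here.

compound 1 `CCCCCCCC(=O)OCC1CN(C(=O)c2cc(OC)c(OC)c(OC)c2)CCN1C(=O)c1cc(OC)c(OC)c(OC)c1` — 310 nM
compound 2 `CCCCCCCCCC(=O)OCC1CN(C(=O)c2cc(OC)c(OC)c(OC)c2)CCN1C(=O)c1cc(OC)c(OC)c(OC)c1` — 2820 nM
compound 3 `COc1cc(C(=O)N2CCN(C(=O)c3cc(OC)c(OC)c(OC)c3)C(COC(=O)CC(C)(C)C)C2)cc(OC)c1OC` — 120 nM

In a functional assay (Oryctolagus cuniculus) for inhibition of platelet-activating factor receptor (Cavia porcellus) (on this read-out higher numbers stand for weaker inhibition and lower numbers for stronger inhibition), compound 3 gives the lowest number of the three measured compounds. Its nearest neighbour is compound 1, and the step of a 2.6-fold lower number from compound 1 to compound 3 (0.41 log units; beyond the scatter) is beyond the scatter. The step of a 24-fold lower number from compound 2 to compound 3 (1.37 log units; beyond the scatter) is larger still, and a 9.1-fold higher number from compound 1 to compound 2 (0.96 log units; beyond the scatter) shows that lengthening the chain moves the number the other way.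

Compound 4 `CCCC(C)NC(=O)OCC1CN(C(=O)c2cc(OC)c(OC)c(OC)c2)CCN1C(=O)c1cc(OC)c(OC)c(OC)c1` has not yet been measured. It differs from compound 3 in one place: (1-methylbutyl)amino in place of neopentyl on a carbonyl carbon. Within the data shown here, none of the measured steps changes a carbon chain into a group carrying nitrogen, so the three steps bear on this change only indirectly: they show that the group on this carbonyl carbon matters, and that the smaller groups in compound 3 and compound 1 gave lower numbers than the longer chain of compound 2. The group entering compound 4 is close in size to the one leaving, so a modest step in this assay at most is expected, in either direction. The estimated step is a 1.7-fold higher number from compound 3 to compound 4 (0.22 log units; within the scatter) for compound 4. Compound 4 is therefore expected to give about 200 nM, within a range of 60 nM to 700 nM.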

Compound 4, half-maximal inhibitory concentration: 100 nM
Compound 4: the middle estimate sits 2.0-fold (0.30 log units) above what was measured; the measured number falls inside the stated range.
By their numbers in this assay, from the lowest: compounds 4 and 3 (each within the scatter of the next); then compound 1; then compound 2.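

In this assay, (1-methylbutyl)amino can take the place of neopentyl on this carbonyl carbon with the numbers staying within the scatter of each other, at a 1.2-fold lower number from compound 3 to compound 4 (0.08 log units; within the scatter), so this position accepts a group carrying nitrogen and a hydrogen-bond donor with no measurable loss of inhibition. The new group also stands clear of both longer chains, with a 3.1-fold lower number from compound 1 to compound 4 (0.49 log units; beyond the scatter) against heptyl and a 28-fold lower number from compound 2 to compound 4 (1.45 log units; beyond the scatter) against nonyl, so the gap that compound 3 showed to those chains is also seen with a group of a different kind on this carbonyl carbon. Nothing measured here accounts for how closely these two groups match.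

The compounds shown leave open whether the hydrogen on the new nitrogen matters, which a dimethylamino group on the same carbonyl carbon would test. They also leave open whether the higher number seen with nonyl returns when a longer chain sits on that nitrogen, as in octylamino, and whether the branching in the 1-methylbutyl group plays any part, which an unbranched pentylamino group would address.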